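The source may report more compounds than this note shows. Statements on the series, on what has been measured and on what is new or still open speak of the compounds shown alone.

Compound 1, `CN1CCN(CCCCCCn2c3c(c4ccccc42)C(=O)c2c[n+]([O-])c4ccccc4c2C3=O)CC1`, gives 630 nM in a functional assay on A-375 cells (Homo sapiens) for cytotoxicity, read by MTT assay, with a stated time of 72 h; a higher number here means a weaker inhibitor, a lower number a stronger inhibitor.
Compound 2, `CN(C)CCCCn1c2c(c3ccccc31)C(=O)c1c[n+]([O-])c3ccccc3c1C2=O`, gives 470 nM in this assay.
Compound 3, `CCCCN1CCN(CCCCn2c3c(c4ccccc42)C(=O)c2c[n+]([O-])c4ccccc4c2C3=O)CC1`, gives 2150 nM in this assay.

Compound 3 has the highest number of the three, so it is the weakest inhibitor here: a 3.4-fold higher number from compound 1 to compound 3 (0.53 log units; beyond the scatter) and a 4.6-fold higher number from compound 2 to compound 3 (0.66 log units; beyond the scatter), both beyond the scatter, while compound 1 and compound 2 lie within the scatter of each other (a 1.3-fold lower number from compound 1 to compound 2 (0.13 log units; within the scatter)).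

Compound 4, `O=C1c2c[n+]([O-])c3ccccc3c2C(=O)c2c1c1ccccc1n2CCCN1CCC(O)CC1`, is not yet measured. Its change from compound 3 is 4-hydroxypiperidin-1-yl in place of (4-butylpiperazin-1-yl)methyl on a saturated chain carbon, three bonds along the chain from an aromatic nitrogen.

The two steps that bear on this are the ones that put the 4-butylpiperazin-1-yl group in place of a smaller amine: from compound 1, a 3.4-fold higher number from compound 1 to compound 3 (0.53 log units; beyond the scatter), and from compound 2, a 4.6-fold higher number from compound 2 to compound 3 (0.66 log units; beyond the scatter). Compound 4 removes that group again, so a modestly lower number in this assay is expected, roughly back toward compound 1 and compound 2, though the shorter chain in compound 4 has no direct parallel among the measured compounds. For compound 4 the expected step is a 3.3-fold lower number from compound 3 to compound 4 (0.52 log units; beyond the scatter), and the estimated value is 650 nM, within 250 nM to 1700 nM.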

Compound 4, half-maximal inhibitory concentration: 240 nM
Estimate against measurement, compound 4: 2.7-fold (0.43 log units) above; the whole stated range lies above it.
By their numbers in this assay, from the lowest: compounds 4, 2 and 1 (each within the scatter of the next, the first and the last beyond it); then compound 3.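

In this assay, 4-hydroxypiperidin-1-yl in place of (4-butylpiperazin-1-yl)methyl gives a 9.0-fold lower number from compound 3 to compound 4 (0.95 log units; beyond the scatter), so a six-membered ring amine at the end of the chain can go with a low number, and the high number of compound 3 is not shared by every ring amine. The comparison with the small dimethylamino end group gives a 2.0-fold lower number from compound 2 to compound 4 (0.29 log units; within the scatter), which leaves the two level, whereas the comparison with the 4-methylpiperazine compound gives a 2.6-fold lower number from compound 1 to compound 4 (0.42 log units; beyond the scatter), a real difference. No measurement shown here explains these differences.

From the compounds shown here alone, each of these steps changes the chain and the end group together, so the share of each remains open. A piperidin-1-yl or 4-methoxypiperidin-1-yl group at this place would test whether the hydroxyl matters.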